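The source may report more compounds than this note shows. Statements on the series, on what has been measured and on what is new or still open speak of the compounds shown alone.

Measured compounds:
compound 1, `COc1cc(/C=N/NC(=O)OCc2ccccc2)cc(OC)c1O`, 69%;
compound 2, `COc1cc(/C=N/NC(=O)OCc2ccccc2)cc(O)c1O`, 57%;
compound 3, `O=C(N/N=C/c1ccc(O)c(O)c1)c1ccncc1`, 101%.

In a functional assay on cells (Mus musculus) for cytotoxicity, read by MTT assay, with a stated time of 24 h, tested at 10 uM (a lower number here means a weaker effect, a higher number a stronger effect of the compound at the concentration tested), compound 2 gives the lowest of the three numbers. Its nearest neighbour is compound 1, which gives 69%, and furthest away is compound 3, which gives 101%, both beyond the scatter from compound 2. The one step that has been measured between two of these compounds, hydrogen in place of methyl on an oxygen on an aromatic ring, gave a number 12 percentage points lower from compound 1 to compound 2 (beyond the scatter).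

Compound 4, `O=C(N/N=C/c1ccc(O)c(O)c1)OCc1ccccc1`, has not yet been measured in this assay. Its difference from compound 2 is hydrogen in place of methoxy on an aromatic carbon. Among the measured compounds shown here, no measured step removes a methoxy group entirely, so the only step that bears on this one is that from compound 1 to compound 2, which changed the same oxygen and was modest. For the measured compounds named here, compound 3 shares the aromatic part of compound 4 but differs elsewhere, and no step connects it to compound 4, so it offers no direct guide. A modest step is therefore expected, with the direction open. The estimate for compound 4 is 62%, in the range 42% to 82%, meaning an expected a number 5 percentage points higher from compound 2 to compound 4 (within the scatter).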

Compound 4, a percentage reported as activity, at one concentration (the size of the read-out at that concentration, not a potency) in the Mus musculus assay: 84%
Estimate against measurement, compound 4: 22 percentage points below, outside the stated range (above it).
By their numbers in the Mus musculus assay, from the lowest: compound 2; then compound 1; then compound 4; then compound 3.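

The earlier step had turned one methoxy group of compound 1 into a hydroxy group and lowered the number. Taking away the remaining methoxy group, so that hydrogen stands on this aromatic carbon, ortho to a hydroxy group, moves the number the other way in the Mus musculus assay, with a number 27 percentage points higher from compound 2 to compound 4 (beyond the scatter). The two steps therefore show that changes at the methoxy groups of these compounds do not all act in one direction, and that complete loss of the group differs from replacing its methyl with hydrogen. In a physicochemical assay, read by spectrophotometry (a higher number here means a weaker inhibitor, a lower number a stronger inhibitor), compound 2 gives 21300 nM and compound 4 gives 7300 nM. The same change also gives the stronger inhibitor in the physicochemical assay, so the effect is not confined to the cell read-out: the measured half-maximal inhibitory concentration of compound 2, 21300 nM, and of compound 4, 7300 nM, a 2.9-fold lower number (0.47 log units; beyond the scatter)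

What the compounds shown leave open is whether fluorine, an ethoxy group or an amine on this aromatic carbon would give numbers closer to those of the methoxy group or of hydrogen in either read-out. They also leave open whether the two read-outs move together in general, as this is the only pair shown with values in both.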